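Sulfonamide series: notes toward compound 4

The compounds below may be only part of what the source reports. "The series", "measured", "known", "first", "only" and "open" are said of these compounds alone.

Compound 1 `Cc1ccc(S(=O)(=O)Nc2ccc3oc(-c4ccccc4)nc3c2)cc1` gives > 100000 nM in an assay on cells for inhibition of HSP60/HSP10 (Homo sapiens), with a stated time of 60 min (a higher number here means a weaker inhibitor, a lower number a stronger inhibitor), which is a limit of the assay and not a number.
Compound 2 `O=S(=O)(Nc1ccc(-c2nc3ccccc3o2)cc1)c1ccccc1Cl` gives > 100000 nM in this assay, again only a limit.
Compound 3 `C=Cc1ccc(S(=O)(=O)Nc2ccc3oc(-c4ccccc4)nc3c2)cc1` gives > 100000 nM in this assay, again only a limit.

Compound 2 thus stands at the limit of > 100000 nM in this assay, at which 3 of the 3 values shown sit, with nothing to separate it from compound 1 or compound 3. Among the measured compounds shown here, the single step between compounds that differ in one place, a step that the two limits leave unreadable from compound 1 to compound 3, runs from one limit to another and its size cannot be read. Compound 4 `CS(=O)(=O)Nc1ccc(-c2nc3ccccc3o2)cc1` differs from compound 2 by methyl in place of 2-chlorophenyl on a sulfonyl sulfur. For the measured compounds named here, no measured step touches the sulfonyl sulfur; the one step available concerns a change on an aromatic carbon and is unreadable, so it gives no direction for this change. Going by the values given here, because every value so far sits at the limit of > 100000 nM in this assay, at which 3 of the 3 values shown sit, compound 4 is expected to give 150000 nM in this assay, with a range from 30000 nM to 1000000 nM, and most probably to be reported as a limit once more. The step this estimate implies, a step that the limit leaves unreadable from compound 2 to compound 4, is expected to be none readable beyond the scatter.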

Compound 4, half-maximal inhibitory concentration: > 100000 nM
Compound 4: only a limit was reported; the forecaster's own chance of this, stated with the estimate: 85%; the middle value does not contradict the limit.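

Compound 4 gives > 100000 nM in this assay, a limit of the assay and not a number. The step from compound 2 to compound 4 runs between two limits and cannot be read. The compounds shown leave open whether any change to this sulfonamide series gives a readable value in this assay.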